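Swapping One Five-Membered Heteroaryl for Another

The source may hold more compounds than are shown below. What is called first, only, known or untested is meant among the compounds shown, and "the series" means these compounds.

Of the compounds shown here, three built on one shared core have been measured in a functional assay for activation of Alpha-1A adrenergic receptor (Homo sapiens), read by calcium flux; a higher number here means that more compound is needed for the effect, a lower number that less compound is needed. Compound 1 `c1cncc(-c2ccccc2OCC2=NCCN2)c1` gives 2 nM in this assay. Compound 3 `c1ccc(-c2ccns2)c(OCC2=NCCN2)c1` gives 5.01 nM in this assay, the higher of the two numbers on hand, and the step of a 2.5-fold higher number from compound 1 to compound 3 (0.40 log units; beyond the scatter) sets it apart from compound 1. For compound 2 `c1ccc(-c2ccncc2)c(OCC2=NCCN2)c1` only a limit of the assay is known, < 100000 nM in this assay. Compound 2 accounts for (the limit of < 100000 nM in this assay, at which 1 of the 3 values shown sits), and for that reason a step that the limit leaves unreadable from compound 1 to compound 2 and a step that the limit leaves unreadable from compound 2 to compound 3 cannot be sized.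

Compound 4 `Cc1csc(-c2ccccc2OCC2=NCCN2)n1` remains to be measured. It differs from compound 3 by 4-methyl-1,3-thiazol-2-yl in place of 1,2-thiazol-5-yl on an aromatic carbon. Among the measured compounds shown here, the only readable step among the measured compounds, a 2.5-fold higher number from compound 1 to compound 3 (0.40 log units; beyond the scatter), was modest, and it exchanged a six-membered ring for a five-membered one; the change to compound 4 keeps a five-membered aromatic ring with 2 hetero atoms and adds a methyl. For the measured compounds named here, no measured step here exchanges one such five-membered ring for another. A step of modest size, or none beyond the scatter, is therefore expected from compound 3 to compound 4, a 1.6-fold higher number from compound 3 to compound 4 (0.20 log units; within the scatter). Compound 4 is estimated at 8 nM in this assay, with an expected range from 2 nM to 40 nM.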

Compound 4, half-maximal effective concentration: 25.1 nM
Beside the measured number, compound 4's estimate is 3.1-fold (0.50 log units) below it; low and high end bracket the measured number.
By their numbers in this assay, from the lowest: compound 1; then compound 3; then compound 4.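

The result shows that this position, on an aromatic carbon ortho to a group of 7 heavy atoms, tells one five-membered aromatic ring with 2 hetero atoms from another in this assay: keeping that ring type still left a 5.0-fold higher number from compound 3 to compound 4 (0.70 log units; beyond the scatter). Ring size and the count of hetero atoms are therefore not enough to hold the number steady here, since 4-methyl-1,3-thiazol-2-yl and 1,2-thiazol-5-yl share both. Against the pyridin-3-yl group, the change gives a 13-fold higher number from compound 1 to compound 4 (1.10 log units; beyond the scatter), the only large step that can be read in this set, while the steps involving compound 2 cannot be read because its value is a limit: the limit of < 100000 nM in this assay, at which 1 of the 4 values shown sits.

The step to compound 4 moves the ring's hetero atoms and adds the methyl in one change, and the compounds shown cannot divide the effect between these two parts. Going by these compounds, how a 1,3-thiazol-2-yl group without the methyl would read stays open, as does the effect of an amine or a longer chain in the methyl's place.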